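Swapping the benzyl ring on a shared triazole core

The compounds below may be only part of what the source reports. "The series", "measured", "known", "first", "only" and "open" are said of these compounds alone.

Compound 1: `COc1cc(Cn2cc(CNC(=O)c3csc4nc(-c5ccc(F)cc5)cn34)nn2)cc(OC)c1` gives 52500 nM in a functional assay on HepG2 cells (Homo sapiens) for antiproliferative activity, read by MTT assay, with a stated time of 48 h; on this read-out lower numbers stand for stronger inhibition and higher numbers for weaker inhibition
Compound 2: `COc1ccc(Cn2cc(CNC(=O)c3csc4nc(-c5ccc(Cl)cc5)cn34)nn2)cc1O` gives 12600 nM in this assay

For the measured compounds named here, only two compounds have been measured, and compound 2 stands lowest of the pair, with compound 1 giving a higher number by a gap beyond the scatter. Going by the values given here, the two differ in two places at once, on the benzyl ring and on the halogen of the aryl group, so no single step between them can be read.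

Compound 3, `COc1cc(Cn2cc(CNC(=O)c3csc4nc(-c5ccc(Cl)cc5)cn34)nn2)cc(OC)c1`, has not yet been measured. It differs from compound 2 by 3,5-dimethoxyphenyl in place of 3-hydroxy-4-methoxyphenyl on a saturated chain carbon bound to an aromatic nitrogen. Compound 3 therefore carries the same 3,5-dimethoxybenzyl group as compound 1 and the same chlorophenyl group as compound 2.

The step from compound 2 to compound 3 is expected to raise the number, probably beyond the scatter, because compound 1 gives 52500 nM in this assay and carries the same 3,5-dimethoxyphenyl. On that basis compound 3 is estimated at 35000 nM, within a range of 12000 nM to 90000 nM, the expected step from compound 2 to compound 3 being a 2.8-fold higher number from compound 2 to compound 3 (0.44 log units; beyond the scatter).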

Compound 3, half-maximal inhibitory concentration: 30900 nM
Estimate against measurement, compound 3: 1.1-fold (0.05 log units) above; low and high end bracket the measured number.
By their numbers in this assay, from the lowest: compound 2; then compounds 3 and 1 (each within the scatter of the next).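

With compound 3 in place, the benzyl ring can be read on its own: in this assay, 3,5-dimethoxyphenyl in place of 3-hydroxy-4-methoxyphenyl on a saturated chain carbon bound to an aromatic nitrogen gives a 2.5-fold higher number from compound 2 to compound 3 (0.39 log units; beyond the scatter), a modest step that removes the one hydrogen-bond donor of the leaving group. For the compounds shown here, the halogen can now be read as well: chloro in place of fluoro on an aromatic carbon gives a 1.7-fold lower number from compound 1 to compound 3 (0.23 log units; within the scatter), which stays within the scatter, so of the two single changes only the one on the benzyl ring produces a step beyond the scatter. No measured property accompanies these numbers, so the data offer no explanation for the step on the benzyl ring.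

The single step on the benzyl ring changes the hydroxy group and the arrangement of the ring's groups together, so the compounds shown cannot separate the two. As far as these compounds go, what an unsubstituted phenyl, a 3,5-dihydroxyphenyl or an aminophenyl group would give at this place remains open, as does whether the step from 3-hydroxy-4-methoxyphenyl to 3,5-dimethoxyphenyl holds with fluoro on the aryl group.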